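Adding a basic chain to compound 3

The compounds below may be only part of what the source reports. "The series", "measured", "known", "first", "only" and "open" are said of these compounds alone.

In a functional assay on KB cells (Homo sapiens) for inhibition, with a stated time of 72 h (on this read-out lower numbers stand for stronger inhibition and higher numbers for weaker inhibition), the measured compounds give these values
- compound 1 `COc1cc(C(=O)n2ccc3ccccc32)cc(OC)c1OC` gives > 10000 nM (a limit of the assay, not a number)
- compound 2 `COc1cc(C(=O)c2cccc3cc[nH]c23)cc(OC)c1OC` gives 310 nM (a measured number)
- compound 3 `COc1cc(C(=O)c2ccc3c(ccn3C)c2)cc(OC)c1OC` gives 13.6 nM (a measured number)

Compound 3 has the lowest number of the three, and its gap to compound 2 lies well beyond the usual scatter of repeated measurements. The next compound to be tested is compound 4 `COc1cc(C(=O)c2ccc3c(ccn3CCN(C)C)c2)cc(OC)c1OC`. It carries (dimethylamino)methyl in place of hydrogen on a saturated chain carbon bound to an aromatic nitrogen. Read one bond further out, this turns methyl into 2-(dimethylamino)ethyl.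

Within the data shown here, no measured pair shows what this change does, so the expectation is only a rough one. A moderate rise in the number, meaning weaker inhibition and a step beyond the scatter, seems most likely. The expected change is a 5.9-fold higher number from compound 3 to compound 4 (0.77 log units; beyond the scatter) in this assay. For compound 4 the estimate is 80 nM (expected range 15 nM to 500 nM) in this same test.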

Compound 4, half-maximal inhibitory concentration: 5200 nM
Compound 4: middle estimate off by 65-fold (1.81 log units), on the low side, and the stated range ends below it.
By their numbers in this assay, from the lowest: compound 3; then compound 2; then compound 4. At a limit, above all of these: compound 1.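

In this assay, among these compounds, the earlier compounds offered no single change to read, whereas this pair isolates one: turning methyl into 2-(dimethylamino)ethyl on the aromatic nitrogen gives a 380-fold higher number from compound 3 to compound 4 (2.58 log units; beyond the scatter). In this pair, then, the position does not tolerate the added chain, and inhibition falls sharply. Compound 4 still gives a measured number, so the size of this step can be read, and the only value at a limit belongs to compound 1: the limit of > 10000 nM in this assay, at which 1 of the 4 values shown sits.

The compounds shown cannot separate the effect of the amine from that of the longer chain, and a plain propyl chain would help to settle this. From the compounds shown here alone, how a chain ending in a hydroxyl group, a carboxylic acid or a morpholine ring would behave at this position also remains open.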